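Methyl for trifluoromethyl on the aryl of compound 1

The source may hold more compounds than are shown below. What is called first, only, known or untested is meant among the compounds shown, and "the series" means these compounds.

Compound 1 `O=C(O)CCc1ccc(OCc2nc(-c3cccc(C(F)(F)F)c3)no2)c(Cl)c1` is tested in a functional assay on CHO cells for agonist activity at Free fatty acid receptor 1 (Homo sapiens), read by FLIPR and calcium flux, in the presence of a further agent that is not named here (on this read-out lower numbers stand for an effect already at smaller amounts and higher numbers for an effect only at larger amounts of compound), where compound 1 gives 30100 nM. Among the three measured compounds, compound 1 gives the highest number: compound 2 `O=C(O)CCc1ccc(OCc2nc(-c3ccc(F)cc3)no2)cc1` gives 680 nM, and compound 3 `CCc1ccc(-c2noc(COc3ccc(CCC(=O)O)cc3)n2)cc1` gives 210 nM, both far below compound 1 and both beyond the scatter.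

Compound 4 `Cc1cccc(-c2noc(COc3ccc(CCC(=O)O)cc3Cl)n2)c1` differs from compound 1 in one place: methyl in place of trifluoromethyl on an aromatic carbon. Of the measured steps, only one touches the same aryl ring, and it is a different exchange: a 3.2-fold lower number from compound 2 to compound 3 (0.51 log units; beyond the scatter), where a small alkyl group replaced a halogen. Among the measured compounds shown here, that step gives only indirect guidance; no measured pair shows methyl in place of trifluoromethyl, and the chloro on the shared core of compound 1 is absent from compounds 2 and 3, so its contribution cannot be separated.

On this basis, compound 4 is expected to give a somewhat lower number than compound 1, with the step estimated as a 3.0-fold lower number from compound 1 to compound 4 (0.48 log units; beyond the scatter). The estimate for compound 4 in this assay is 10000 nM, with a range from 3000 nM to 40000 nM.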

Compound 4, half-maximal effective concentration: 4580 nM
Beside the measured number, compound 4's estimate is 2.2-fold (0.34 log units) above it; measured number inside the range.
By their numbers in this assay, from the lowest: compound 3; then compound 2; then compound 4; then compound 1.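

In this assay the exchange of trifluoromethyl for methyl, on an aromatic carbon meta to a large group, gives a 6.6-fold lower number from compound 1 to compound 4 (0.82 log units; beyond the scatter) on an otherwise unchanged core. Among the compounds shown here, this is the first measured pair that isolates a change at this position, and it shows that this single exchange, with the chloro of the shared core kept in place, moves the number beyond the usual scatter. The earlier step, a 3.2-fold lower number from compound 2 to compound 3 (0.51 log units; beyond the scatter), involved a different exchange on a core without that chloro, so it could not show this; the compounds shown offer no measured basis for explaining the effect of the present exchange.

The compounds shown leave open whether ethyl, methoxy or a nitrile in this same place would give a lower or higher number than methyl. They also leave open whether methyl in place of trifluoromethyl would give a step of similar size on a core that lacks the chloro.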